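A few compounds are considered here, and "the series" means these few. Any claim that something is new, unique, unknown or untested is made for them only; others in the source may bear on it.

Measured so far:
- compound 1, `CCCCC(=O)N[C@H]1[C@@H](OCCc2ccccc2)O[C@H](COCC(CO)(CO)COS(=O)(=O)O)[C@@H](O)[C@@H]1O`: 9.3 uM
- compound 2, `CCCCCCCCCCCCCCCCO[C@H]1O[C@H](COCC(CO)(CO)COS(=O)(=O)O)[C@@H](O)[C@H](O)[C@H]1NC(=O)CCCC`: 2.3 uM

In a functional assay on A-375 cells (Homo sapiens), read by thymidine incorporation (a higher number here means a weaker inhibitor, a lower number a stronger inhibitor), compound 1 gives 9.3 uM, the highest of the two numbers recorded; compound 2 gives 2.3 uM, and the gap between compound 1 and compound 2 lies beyond the scatter. The two differ at more than one place, so nothing is attributed to any single change between them.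

Compound 3, `CCCCC(=O)N[C@H]1[C@@H](OCCc2ccccc2)O[C@H](COCC(CO)(CO)CO)[C@@H](O)[C@@H]1O`, is not yet measured. It differs from compound 1 by hydrogen in place of sulfo on an oxygen on a saturated carbon; read one bond further out, sulfooxy becomes hydroxy. Within the data shown here, no measured pair shows this change, so its direction is unknown. The expectation is a small shift from compound 1 to compound 3, close to the scatter, with a weaker inhibitor slightly more likely: the expected step is a 1.6-fold higher number from compound 1 to compound 3 (0.21 log units; within the scatter). In this assay compound 3 is estimated at 15 uM, with a range from 5 uM to 45 uM.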

Compound 3, concentration for 50% inhibition: > 50 uM
Compound 3: only a limit was reported; the forecaster's own chance of this, stated with the estimate: 10%; middle value at least 3.3-fold (0.52 log units) from the limit.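

In this assay, compound 3 gives > 50 uM, which is a limit of the assay and not a number. Hydrogen in place of sulfo on this oxygen, with sulfooxy becoming hydroxy, gives an at least 5.3-fold higher number from compound 1 to compound 3 (0.73 log units; beyond the scatter); this is the first reading at this position in the series, and it shows that removing the sulfo group here produces a loss beyond the scatter. Only a lower bound on that step can be read, not its full size: the limit of > 50 uM in this assay, at which 1 of the 3 values shown sits.

The compounds shown leave open whether another group on this oxygen, such as a phosphate, a carboxylic acid or an amine, would keep the activity. They also leave open whether the same change on compound 2 would produce a step of similar size.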